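Replacing the naphthyl ether with a tolyl ether in a thiosemicarbazone

The source may hold more compounds than are shown below. What is called first, only, known or untested is meant among the compounds shown, and "the series" means these compounds.

Measured compounds:
compound 1, `S=C(N/N=C/c1ccc(Oc2ccc(Br)cc2)cc1)Nc1ccccc1`, 5.62
compound 2, `S=C(N/N=C/c1ccc(Oc2ccc3ccccc3c2)cc1)Nc1ccc(Cl)cc1`, 6.96
compound 3, `S=C(N/N=C/c1ccc(Oc2ccc3ccccc3c2)cc1)Nc1ccccc1`, 6.07

In a physicochemical assay for lipophilicity, in phosphate buffer, measured as octanol-water partition, with a stated time of 24 h (a higher number here means a more lipophilic compound, a lower number a more polar compound), compound 2 gives the highest of the three numbers; compound 3 is the nearest and lies lower by a step beyond the scatter, compound 1 lies lowest. Among the measured compounds shown here, the one measured step that differs in a single place, a number 0.89 log units lower from compound 2 to compound 3 (beyond the scatter), concerns the chloro on the aniline ring, not the aryl ether. Compound 4, `Cc1ccc(Oc2ccc(/C=N/NC(=S)Nc3ccc(Cl)cc3)cc2)cc1`, differs from compound 2 as 4-methylphenyl in place of naphthalen-2-yl on an oxygen on an aromatic ring. For the measured compounds named here, no measured step isolates this change. Compounds 1 and 3 share the unsubstituted aniline and differ only in the aryl on the oxygen: compound 1 gives 5.62 and compound 3 gives 6.07, with the smaller aryl lower. For compound 4 a step downward from compound 2 beyond the scatter is therefore expected, and the estimated step is a number 0.76 log units lower from compound 2 to compound 4 (beyond the scatter). Compound 4 is expected to give about 6.2 in this assay, within a range from 5.7 to 6.7.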

Compound 4, partition coefficient: 5.97
For compound 4 the middle estimate is 0.23 log units above the measured one; the range from low to high includes it.
By their numbers in this assay, from the lowest: compound 1; then compounds 4 and 3 (each within the scatter of the next); then compound 2.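

In this assay the change on the oxygen now has a step of its own, with the chloro on the aniline ring held in place: a number 0.99 log units lower from compound 2 to compound 4 (beyond the scatter). This exchange of naphthalen-2-yl for 4-methylphenyl, with one aromatic ring in place of two, is beyond the scatter, as is the step at the chloro, a number 0.89 log units lower from compound 2 to compound 3 (beyond the scatter), so both places in the molecule move this number. Nothing available here accounts for the size of the step on the oxygen.

Going by these compounds, what a plain phenyl, or a phenyl carrying a methoxy group or an amine in place of the methyl, would give in this assay remains open. So does whether the same exchange gives a step of this size when hydrogen replaces the chloro.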